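A few compounds are considered here, and "the series" means these few. Any claim that something is new, unique, unknown or untested is made for them only; others in the source may bear on it.

Working notes on the series. Compound 3 `CCOC(=O)c1sc(-c2ccncc2)nc1N1CCC(NCc2ccccc2)CC1` gives 10.8% in an ADME assay on RAW264.7 cells (Mus musculus) for cytotoxicity, read by MTT assay, with a stated time of 72 h, tested at 50 uM; on this read-out higher numbers stand for more inhibition at the one concentration tested (going by the name of the read-out) and lower numbers for less inhibition. Among the three measured compounds, compound 3 is second highest; compound 2 `CCOC(=O)c1sc(-c2ccccn2)nc1N1CCC(NCc2ccc(F)cc2)CC1` gives 12.6% and compound 1 `CCOC(=O)c1sc(-c2ccccc2)nc1N1CCC(NCc2ccc(F)cc2)CC1` gives 6.23%, both within the scatter of compound 3. Going by the values given here, the only single-point step measured, a number 6.4 percentage points higher from compound 1 to compound 2 (within the scatter), concerns the aryl group and lies within the scatter. Compound 4 `CCOC(=O)c1sc(-c2ccncc2)nc1N1CCC(NCc2ccc(F)cc2)CC1` differs from compound 3 by fluoro in place of hydrogen on an aromatic carbon. Among the compounds with values here, no measured step touches this change: compound 1 and compound 3 carry it together with an aryl swap, so their values show nothing on their own. Within the data shown here, with no bearing step and all values close, a step of a number 0.2 percentage points higher from compound 3 to compound 4 (within the scatter) is expected, within the scatter. Compound 4 is estimated at 11%, between 3% and 20%.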

Compound 4, a percentage reported as inhibition, at one concentration (the size of the read-out at that concentration, not a potency): 17.5%
Compound 4: middle estimate off by 6.5 percentage points, on the low side, and the stated range covers the measured number.
By their numbers in this assay, from the lowest: compounds 1, 3, 2 and 4 (each within the scatter of the next, the first and the last beyond it).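

In this assay, fluoro in place of hydrogen, para to a large group, now has its own reading: a number 6.7 percentage points higher from compound 3 to compound 4 (within the scatter), so benzyl and 4-fluorobenzyl cannot be told apart here. Going by these compounds alone, with the 4-fluorobenzyl group held constant, pyridin-4-yl and pyridin-2-yl also stay unresolved, giving a number 4.9 percentage points higher from compound 2 to compound 4 (within the scatter), whereas the change from phenyl to pyridin-4-yl gives a number 11.3 percentage points higher from compound 1 to compound 4 (beyond the scatter), the only step beyond the scatter. No supporting measurement accounts for this step.

From the compounds shown here alone, it remains open whether chloro or methoxy at the fluoro position would move the read-out beyond the scatter. Going by these compounds, the effect of a carboxylic acid in place of the ethyl ester also remains open.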